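A few compounds are considered here, and "the series" means these few. Any claim that something is new, unique, unknown or untested is made for them only; others in the source may bear on it.

The measured compounds in this set:

Compound 1 `O=C(Cn1c(-c2ccccc2)cc(-c2ccccc2)c1-c1ccco1)Nc1nc2ccccc2s1`. In an ADME assay on HEK-293T cells (Homo sapiens) for cytotoxicity, read by MTT assay, with a stated time of 72 h (a lower number here means a stronger inhibitor, a higher number a weaker inhibitor), compound 1 gives < 50000 nM, which is a limit of the assay and not a number.
Compound 2 `CCc1nnc(NC(=O)Cn2c(-c3ccccc3)cc(-c3ccccc3)c2-c2ccco2)s1`. In this assay compound 2 gives < 50000 nM, again a limit.
Compound 3 `O=C(Cn1c(-c2ccccc2)cc(-c2ccccc2)c1-c1ccco1)NCc1ccccc1`. In this assay compound 3 gives < 50000 nM, also a limit.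

Compound 1 therefore stands only at a limit in this assay, and it shares that position with every other value shown: the limit of < 50000 nM in this assay, at which 3 of the 3 values shown sit. The three compounds differ only in the group on the amide-type nitrogen, and none of those steps can be read from two limits: a step that the two limits leave unreadable from compound 1 to compound 2, a step that the two limits leave unreadable from compound 1 to compound 3 and a step that the two limits leave unreadable from compound 2 to compound 3.

Compound 4 `O=C(Cn1c(-c2ccccc2)cc(-c2ccccc2)c1-c1ccccc1)Nc1nc2ccccc2s1` keeps the amide part of compound 1 and alters the shared core instead: phenyl in place of furan-2-yl on an aromatic carbon. Among the compounds with values here, no measured step touches this position, and the steps that were measured, all on the amide nitrogen, are unreadable in size. So there is no basis for expecting a change in either direction beyond the scatter, and the step from compound 1 is expected to be a number no lower from compound 1 to compound 4 (the limit leaves the size open). Compound 4 is estimated to give 50000 nM in this assay, with a range from 20000 nM to 100000 nM, most probably reported once more only as a limit.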

Compound 4, half-maximal inhibitory concentration: < 50000 nM
Compound 4: no number, only a limit (the forecaster's own chance of this, stated with the estimate: 85%); the middle value sits exactly at the limit.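

In this assay compound 4 gives < 50000 nM, which is a limit of the assay and not a number. Compound 1 also stands only at a limit, so the size of the change from compound 1 to compound 4 cannot be read, and all the compounds share one position: the limit of < 50000 nM in this assay, at which 4 of the 4 values shown sit. The compounds shown leave open whether phenyl in place of furan-2-yl, or any change of the group on the amide nitrogen, alters the read-out at all, and by how much.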